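The source may report more compounds than this note shows. Statements on the series, on what has been measured and on what is new or still open speak of the compounds shown alone.

Measured compounds:
Compound 1 `C=CC(C)(C)c1[nH]c2ccccc2c1/C=C1\NC(=O)C(C)(OC)NC1=O` gives 99000 nM in a functional assay; a lower number here means a stronger inhibitor, a higher number a weaker inhibitor.
Compound 2 `C=CC(C)(C)c1[nH]c2ccc(CC=C(C)C)cc2c1/C=C1\NC(=O)C(C)(OC)NC1=O` gives 79000 nM in this assay.
Compound 3 `C=CC(C)(C)c1[nH]c2c(CC=C(C)C)cc(CC=C(C)C)cc2c1/C=c1\[nH]c(=O)c(=C)[nH]c1=O` gives 43000 nM in this assay.

Compound 2 and compound 1 differ in one place, (hydrogen in place of 3-methylbut-2-en-1-yl on an aromatic carbon), and the step is a 1.3-fold higher number from compound 2 to compound 1 (0.10 log units; within the scatter). Compound 3 carries a different core from compound 2; the difference between the two cores is not broken down here. In this assay compound 3 gives the lowest number of the three, though its gap to compound 2 lies within the scatter and only its gap to compound 1 lies beyond it.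

Compound 4 `C=CC(C)(C)c1[nH]c2ccc(CC=C(C)C)cc2c1/C=c1\[nH]c(=O)c(=C)[nH]c1=O` is not yet measured. It differs from compound 3 by hydrogen in place of 3-methylbut-2-en-1-yl on an aromatic carbon. Among the measured compounds shown here, this is the same kind of change as the one from compound 2 to compound 1, but the surroundings of the place are not identical: in compound 3 the leaving group sits ortho to a fused ring, meta to a 3-methylbut-2-en-1-yl group and meta to a fused ring, whereas in compound 2 it sits meta to a fused ring and para to a fused ring.

Since the earlier step was a 1.3-fold higher number from compound 2 to compound 1 (0.10 log units; within the scatter), compound 4 is expected to move by about a 1.3-fold higher number from compound 3 to compound 4 (0.11 log units; within the scatter) from compound 3, because 43000 nM leaves little room for a marked change of the same kind. The estimate for compound 4 in this assay is 55000 nM, with a range from 25000 nM to 120000 nM expected.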

Compound 4, half-maximal inhibitory concentration: 60000 nM
Compound 4: the middle estimate sits 1.1-fold (0.04 log units) below what was measured; the measured number falls inside the stated range.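

In this assay, putting hydrogen in place of 3-methylbut-2-en-1-yl on the aromatic carbon gives a 1.4-fold higher number from compound 3 to compound 4 (0.14 log units; within the scatter), so on the core of compound 3 this change leaves the number indistinguishable from that of its parent. The same exchange on the core of compound 1 behaves alike, and the two steps do not differ beyond what repeated measurement would produce: the same change on two cores in this assay, a 1.3-fold higher number (0.10 log units; within the scatter) from compound 2 to compound 1 and a 1.4-fold higher number (0.14 log units; within the scatter) from compound 3 to compound 4, 1.1-fold (0.05 log units) apart, within the scatter of two such steps This shows that the change can be carried from one core to the other without a visible difference in outcome, but because neither step stands clear of the scatter, it does not show that a real effect of fixed size transfers, and two pairs, with the group leaving from differently surrounded places, cannot establish a rule for the series.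

Going by these compounds, it remains open how the core of compound 3 would read with hydrogen on both of the aromatic carbons that carry 3-methylbut-2-en-1-yl in compound 3, and whether the place described here matters at all for this read-out. Also open, on these data alone, is whether a different group on that carbon, such as an amine, a carboxylic acid or a longer chain, would move the number beyond the scatter.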